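The source may hold more compounds than are shown below. What is called first, only, known or untested is meant among the compounds shown, and "the series" means these compounds.

In an ADME assay on microsomes from liver for inhibition of cytochrome P450 2B1 (Rattus norvegicus) (on this read-out higher numbers stand for weaker inhibition and lower numbers for stronger inhibition), compound 1 `CC(C)c1nc2ccccc2[nH]1` gives 537000 nM, while compound 2 `CCCCCCc1nc2ccccc2[nH]1` gives 32400 nM. Compound 2 thus stands lowest of the two numbers, its nearest neighbour being compound 1, a gap beyond the usual scatter. Within the data shown here, compound 3 `CCCCCCCCCCCCCc1nc2ccccc2[nH]1` differs from compound 2 by heptyl in place of hydrogen on a saturated chain carbon, six bonds along the chain from an aromatic carbon, and no measured step of this kind exists. Because compound 2 gives 32400 nM against the higher number of compound 1, the longer chain is expected to move the number further down, a step of a 2.7-fold lower number from compound 2 to compound 3 (0.43 log units; beyond the scatter) in this assay. Compound 3 is therefore estimated at 12000 nM, within 2500 nM to 60000 nM.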

Compound 3, half-maximal inhibitory concentration: 22900 nM
Compound 3: the middle estimate sits 1.9-fold (0.28 log units) below what was measured, and the stated range covers the measured number.
By their numbers in this assay, from the lowest: compounds 3 and 2 (each within the scatter of the next); then compound 1.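

In this assay, heptyl in place of hydrogen on a saturated chain carbon, six bonds along the chain from an aromatic carbon, gives a 1.4-fold lower number from compound 2 to compound 3 (0.15 log units; within the scatter) and so leaves compound 2 and compound 3 indistinguishable on this read-out. The earlier compounds shown here did not show that this position takes so large a chain extension with no step beyond the scatter. Nothing measured here accounts for this result. The compounds shown leave open whether an amine or a carboxylic acid at the end of the chain would likewise stay within the scatter.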